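A few compounds are considered here, and "the series" means these few. Any claim that something is new, unique, unknown or untested is made for them only; others in the source may bear on it.

In a functional assay on CFPAC-1 cells (Homo sapiens) for inhibition, read by MTT assay, with a stated time of 72 h (on this read-out lower numbers stand for stronger inhibition and higher numbers for weaker inhibition), compound 3 `Cc1ccc(S(=O)(=O)NCc2cn(Cc3cc(=O)oc4cc(O)ccc34)nn2)cc1` gives 68900 nM. Compound 2 `CCCC1CCC(c2ccc(-c3cn(Cc4cc(=O)oc5cc(O)ccc45)nn3)cc2)CC1` gives 52800 nM in the same test, a gap that sits within the usual scatter, so the two cannot be ranked against each other. Compound 1 `CC(O)c1cn(Cc2cc(=O)oc3cc(O)ccc23)nn1` reaches only > 100000 nM, which is a limit of the method rather than a number (the limit of > 100000 nM in this assay, at which 1 of the 3 values shown sits). Compound 4 `O=c1cc(Cn2cc(CNS(=O)(=O)c3ccc(F)cc3)nn2)c2ccc(O)cc2o1` differs from compound 3 by fluoro in place of methyl on an aromatic carbon. Among the measured compounds shown here, no measured pair shows this exchange, so the step from compound 3 to compound 4 in this assay is expected to be a 1.0-fold higher number from compound 3 to compound 4 (0.01 log units; within the scatter), nothing beyond the scatter in either direction. Compound 4 is accordingly estimated at 70000 nM, with a likely range from 30000 nM to 160000 nM.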

Compound 4, half-maximal inhibitory concentration: > 100000 nM
Compound 4: no number, only a limit (the forecaster's own chance of this, stated with the estimate: 30%); middle value at least 1.4-fold (0.15 log units) from the limit.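

In this assay compound 4 gives > 100000 nM, which is a limit of the assay and not a number. Among the compounds shown here, at this place on the aromatic carbon, the first reading of fluoro in place of methyl is an at least 1.4-fold higher number from compound 3 to compound 4 (0.16 log units; that floor lies within the scatter); it shows no stronger inhibition with fluoro, and how much weaker compound 4 may be cannot be read. The series now has more compounds without an exact value: the limit of > 100000 nM in this assay, at which 2 of the 4 values shown sit.

From the compounds shown here alone, what a methoxy group or an amine at the same place would do remains open. So does whether any group here could give clearly stronger inhibition than the methyl of compound 3.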